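A few compounds are considered here, and "the series" means these few. Any claim that something is new, unique, unknown or untested is made for them only; others in the source may bear on it.

In an ADME assay on microsomes from liver (Homo sapiens) for metabolic stability, read by LC-MS, with a stated time of 10 min, tested at 0.5 uM (on this read-out higher numbers stand for a more stable compound and lower numbers for a less stable compound), compound 1 (`c1ccc2c(c1)CN[C@H](CN(CCCN1CCNCC1)[C@H]1CCCc3cccnc31)C2`) gives 99% as the highest of the three numbers in hand, beyond the scatter from both of the others. Compound 2 (`c1ccc2c(c1)CN[C@@H](CN(CCC1CCNCC1)[C@H]1CCCc3cccnc31)C2`) stands at 66% and compound 3 (`CN1CCN(CCCN(C[C@H]2Cc3ccccc3CN2C)[C@H]2CCCc3cccnc32)CC1`) at 60% on the same read-out. Compound 4 (`c1cnc2c(c1)CN[C@@H](CN(CCCN1CCNCC1)[C@H]1CCCc3cccnc31)C2`) has not been measured yet, and its difference from compound 1 is this (a group of 10 heavy atoms (8 carbon, 2 nitrogen; one six-membered non-aromatic ring with 1 hetero atom, one six-membered aromatic ring with 1 hetero atom) in place of a group of 10 heavy atoms (9 carbon, 1 nitrogen; one six-membered non-aromatic ring with 1 hetero atom, one six-membered aromatic ring of carbon only), on a saturated chain carbon bound to an amine nitrogen) with a six-membered aromatic ring with 1 hetero atom entering. Among the measured compounds shown here, no measured pair shows this kind of change, so the expectation rests on the high starting value alone. The estimated step (a number 11 percentage points lower from compound 1 to compound 4 (beyond the scatter)) is a modest fall in this assay that may barely clear the scatter. For compound 4 the expected value is 88% within an estimated range from 70% to 100% as it stands now.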

Compound 4, percent of the compound remaining: 79%
Compound 4: middle estimate off by 9 percentage points, on the high side; low and high end bracket the measured number.
By their numbers in this assay, from the lowest: compounds 3 and 2 (each within the scatter of the next); then compound 4; then compound 1.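

In this assay, this position on a saturated chain carbon bound to an amine nitrogen proves sensitive to a single ring change: replacing the 1,2,3,4-tetrahydroisoquinolin-3-yl group with the group whose aromatic ring holds one hetero atom gives a number 20 percentage points lower from compound 1 to compound 4 (beyond the scatter). This is the only step shown that can be read at one place, and nothing at hand explains it. From the compounds shown here alone, whether a fluorine on the carbon-only aromatic ring or a pyrimidine ring in its place would behave alike remains open, as does whether this change would give a similar step with the side chains of compound 2 or compound 3.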